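The compounds below may be only part of what the source reports. "The series", "measured", "known", "first", "only" and "open" are said of these compounds alone.

Measured compounds:
- compound 1 `COC(CN(c1ccccc1CO)S(=O)(=O)c1ccc([N+](=O)[O-])cc1)n1cnc2c(Cl)ncnc21`: 18700 nM
- compound 2 `Ic1ncnc2ncn(C3COc4ccccc4CO3)c12`: 1250 nM
- compound 3 `COC(CN(c1ccccc1CO)S(=O)(=O)c1ccccc1[N+](=O)[O-])n1cnc2c(Cl)ncnc21`: 11300 nM; 3250 nM (2 entries)

In a functional assay on MCF7 cells (Homo sapiens) for antiproliferative activity (on this read-out lower numbers stand for stronger inhibition and higher numbers for weaker inhibition), compound 1 gives 18700 nM, the highest of the two single numbers recorded there. Its nearest neighbour, compound 2, gives 1250 nM, a lower number by a margin beyond the usual scatter. Compound 3 has been measured more than once, and its two entries, (the several entries of compound 3 in this assay, 11300 nM; 3250 nM (2 entries)), spread widely enough that no single number can be fixed for it. No pair among these three differs in only one place, so no measured step is available to lean on.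

Compound 4 `COC(CN(c1ccccc1CO)S(=O)(=O)c1ccc([N+](=O)[O-])cc1)n1cc(F)c(=O)[nH]c1=O` is the unmeasured compound. It differs from compound 1 by a group of 9 heavy atoms (4 carbon, 2 nitrogen, 2 oxygen, 1 fluorine; one six-membered aromatic ring with 2 hetero atoms) in place of a group of 10 heavy atoms (5 carbon, 4 nitrogen, 1 chlorine; one five-membered aromatic ring with 2 hetero atoms, one six-membered aromatic ring with 2 hetero atoms), on a saturated chain carbon bound to an oxygen on a saturated carbon and a saturated chain carbon. The sulfonamide, the nitrophenyl group, the hydroxymethylphenyl group and the methoxy-bearing chain are kept.

With no measured step of this kind and with compound 1 itself standing at the weak end of the numbers shown, no step beyond the scatter is expected from compound 1 to compound 4 in this assay; the change is expected to leave the number close to where compound 1 sits. Compound 4 is estimated at 15000 nM, within a range from 3000 nM to 60000 nM, which corresponds to an expected step of a 1.2-fold lower number from compound 1 to compound 4 (0.10 log units; within the scatter).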

Compound 4, half-maximal inhibitory concentration: 55200 nM
Compound 4: the middle estimate sits 3.7-fold (0.57 log units) below what was measured; the range from low to high includes it.
By their numbers in this assay, from the lowest: compound 2; then compound 1; then compound 4.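

In this assay the place on a saturated chain carbon bound to an oxygen on a saturated carbon and a saturated chain carbon now has its first measured step: replacing the group with one five-membered and one six-membered aromatic ring by the group with a single six-membered aromatic ring gives a 3.0-fold higher number from compound 1 to compound 4 (0.47 log units; beyond the scatter) and so moves the number toward weaker inhibition. This shows that the number responds to what sits at this place, even in a compound already at the weak end of those shown, whereas the earlier compounds offered no pair differing only here. The step remains a single modest one, and repeat entries in this assay can lie far apart: the several entries of compound 3 in this assay, 11300 nM; 3250 nM (2 entries).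

Because the two groups differ in their rings, their halogen and their hydrogen-bond donors all at once, the compounds shown do not tell which of these differences goes with the step. As far as these compounds go, whether a smaller group at this place, such as an amine or a carboxylic acid, would give a lower or a higher number than compound 1 also stays open.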